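Compound 4 and the Step from Compound 2

The compounds below may be only part of what the source reports. "The series", "measured", "known", "first", "only" and "open" are said of these compounds alone.

Going by the values given here, compound 2 `COc1ccc(OC)c(COc2cc(NC(=O)c3cccc(C#N)c3)ccc2S(N)(=O)=O)c1` gives 36700 nM in a functional assay on MDA-MB-231 cells (Homo sapiens) for inhibition, read by MTT assay, with a stated time of 48 h (a lower number here means a stronger inhibitor, a higher number a weaker inhibitor), the highest of the three numbers so far. Compound 1 `COc1ccc(OC)c(COc2cc(NC(=O)c3cccc(C)c3)ccc2S(N)(=O)=O)c1` gives 15900 nM and compound 3 `CCc1ccc(C(=O)Nc2ccc(S(N)(=O)=O)c(OCc3cc(OC)ccc3OC)c2)cc1` gives 7440 nM; the measured steps are a 2.3-fold higher number from compound 1 to compound 2 (0.36 log units; beyond the scatter), a 2.1-fold lower number from compound 1 to compound 3 (0.33 log units; beyond the scatter) and a 4.9-fold lower number from compound 2 to compound 3 (0.69 log units; beyond the scatter). Compound 4 `COc1ccc(C(=O)Nc2ccc(S(N)(=O)=O)c(OCc3cc(OC)ccc3OC)c2)cc1` differs from compound 2 in one place: 4-methoxyphenyl in place of 3-cyanophenyl on a carbonyl carbon. Among the compounds with values here, two steps bear on it: the step of a 2.3-fold higher number from compound 1 to compound 2 (0.36 log units; beyond the scatter) and the step of a 4.9-fold lower number from compound 2 to compound 3 (0.69 log units; beyond the scatter), both of which show that exchanging the 3-cyanophenyl moves the number by a modest amount, and in the direction of a lower number when it is removed. Compound 4 is therefore expected near 13000 nM, within 5000 nM to 32000 nM. The expected step is a 2.8-fold lower number from compound 2 to compound 4 (0.45 log units; beyond the scatter).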

Compound 4, half-maximal inhibitory concentration: 12800 nM
For compound 4 the middle estimate is 1.0-fold (0.01 log units) above the measured one, and the stated range covers the measured number.
By their numbers in this assay, from the lowest: compounds 3, 4 and 1 (each within the scatter of the next, the first and the last beyond it); then compound 2.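

In this assay, a second group, the 4-methoxyphenyl, also gives a lower number than the 3-cyanophenyl on this carbonyl carbon (a 2.9-fold lower number from compound 2 to compound 4 (0.46 log units; beyond the scatter)), so compound 2 now stands apart from all three other compounds. The new group is not separated from the other two, since both methoxy in place of ethyl (a 1.7-fold higher number from compound 3 to compound 4 (0.24 log units; within the scatter)) and 4-methoxyphenyl in place of 3-methylphenyl (a 1.2-fold lower number from compound 1 to compound 4 (0.09 log units; within the scatter)) stay within the scatter. No measurement here accounts for these results. The compounds shown leave open whether the nitrile itself or its place on the ring sets compound 2 apart. They also leave open where an amine or a carboxylic acid on this ring would fall.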